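Swapping 4-fluorophenyl for 3-chlorophenyl

This account rests on a few compounds, and the source may have more. Where it says the series, first, only, none or still open, it means among the compounds named here.

In a functional assay on A-375 cells (Homo sapiens) for cytotoxicity, read by CCK-8 assay, with a stated time of 24 h (a lower number here means a stronger inhibitor, a higher number a weaker inhibitor), compound 3 `COc1ccccc1Oc1c(N)nc(-c2ccc(F)cc2)nc1Cl` gives 28200 nM, and compound 1 `COc1cccc(-c2nc(N)c(Oc3ccccc3OC)c(Cl)n2)c1` gives 24600 nM. These two values lie within the scatter of each other. Compound 2 `COc1ccc(-c2nc(N)c(Oc3ccccc3OC)c(Cl)n2)cc1` reaches only a limit of the assay, > 80000 nM.

Compound 4 `COc1ccccc1Oc1c(N)nc(-c2cccc(Cl)c2)nc1Cl` carries 3-chlorophenyl in place of 4-fluorophenyl on an aromatic carbon. For the measured compounds named here, three measured steps bear on this change: a 1.1-fold higher number from compound 1 to compound 3 (0.06 log units; within the scatter), an at least 3.2-fold higher number from compound 1 to compound 2 (0.51 log units; beyond the scatter) and an at least 2.8-fold lower number from compound 2 to compound 3 (0.45 log units; beyond the scatter). Going by the values given here, only the steps involving compound 2 exceed the scatter, and 4-methoxyphenyl is not part of this change, so this assay is expected to show little movement. The expected step is a 1.2-fold lower number from compound 3 to compound 4 (0.09 log units; within the scatter). Compound 4 is estimated at 23000 nM, within an expected range of 10000 nM to 52000 nM.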

Compound 4, half-maximal inhibitory concentration: 38300 nM
Estimate against measurement, compound 4: 1.7-fold (0.22 log units) below, within the range that was stated.
By their numbers in this assay, from the lowest: compounds 1, 3 and 4 (each within the scatter of the next). At a limit, above all of these: compound 2.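

At this position, between two ring nitrogen atoms, 3-chlorophenyl falls in with 4-fluorophenyl and 3-methoxyphenyl in this assay: the change gives a 1.4-fold higher number from compound 3 to compound 4 (0.13 log units; within the scatter), and the comparison with the 3-methoxyphenyl compound gives a 1.6-fold higher number from compound 1 to compound 4 (0.19 log units; within the scatter). Among the groups shown, only 4-methoxyphenyl stands apart, with 3-chlorophenyl in its place giving an at least 2.0-fold lower number from compound 2 to compound 4 (0.31 log units; beyond the scatter). That step rests on a limit of the assay, not on a number: the limit of > 80000 nM in this assay, at which 1 of the 4 values shown sits.

The compounds shown leave open whether a group other than a substituted phenyl, such as an amine or a carboxylic acid, would shift the number at this position.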